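From 4-chlorobenzyl to 3-(trifluoromethyl)benzyl: an expected step

The source may report more compounds than this note shows. Statements on the series, on what has been measured and on what is new or still open speak of the compounds shown alone.

- compound 1 `COc1cc(OC)c(-c2coc3cc(OCC=C(C)C)ccc3c2=O)cc1OC`: 680 nM
- compound 2 `COc1cc(OC)c(-c2coc3cc(OCc4ccccc4)ccc3c2=O)cc1OC`: 2280 nM
- compound 3 `COc1cc(OC)c(-c2coc3cc(OCc4ccc(Cl)cc4)ccc3c2=O)cc1OC`: 4450 nM

These numbers come from a functional assay on HCT-116 cells (Homo sapiens) for antiproliferative activity, read by MTT assay, with a stated time of 24 h; on this read-out lower numbers stand for stronger inhibition and higher numbers for weaker inhibition. Compound 3 sits within the scatter of compound 2, while a 6.5-fold higher number from compound 1 to compound 3 (0.82 log units; beyond the scatter) lies beyond it. Compound 4 `COc1cc(OC)c(-c2coc3cc(OCc4cccc(C(F)(F)F)c4)ccc3c2=O)cc1OC` carries 3-(trifluoromethyl)phenyl in place of 4-chlorophenyl, on a saturated chain carbon bound to an oxygen on an aromatic ring: 3-(trifluoromethyl)phenyl in place of 4-chlorophenyl on a saturated chain carbon bound to an oxygen on an aromatic ring. The closest measured change is chloro in place of hydrogen, giving a 2.0-fold higher number from compound 2 to compound 3 (0.29 log units; within the scatter) within the scatter. The modest 3.4-fold higher number from compound 1 to compound 2 (0.53 log units; beyond the scatter) instead replaced 2-methylprop-1-en-1-yl, which this change leaves untouched. Among the measured compounds shown here, no measured compound carries trifluoromethyl, so confidence is limited, but no step beyond the scatter is expected in this assay. The expected change is a 1.1-fold lower number from compound 3 to compound 4 (0.05 log units; within the scatter). The estimate for compound 4 is 4000 nM, with an expected range of 1700 nM to 9500 nM.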

Compound 4, half-maximal inhibitory concentration: 3400 nM
Compound 4: the middle estimate sits 1.2-fold (0.07 log units) above what was measured; low and high end bracket the measured number.
By their numbers in this assay, from the lowest: compound 1; then compounds 2, 4 and 3 (each within the scatter of the next).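

In this assay the move from 4-chlorobenzyl to 3-(trifluoromethyl)benzyl gives a 1.3-fold lower number from compound 3 to compound 4 (0.12 log units; within the scatter) and so changes little, while trifluoromethyl in place of hydrogen gives a 1.5-fold higher number from compound 2 to compound 4 (0.17 log units; within the scatter). A second substituted benzyl group thus also stays within the scatter of the plain benzyl of compound 2, and a 5.0-fold higher number from compound 1 to compound 4 (0.70 log units; beyond the scatter) keeps it apart from compound 1, with its 2-methylprop-1-en-1-yl group. No evidence here explains these results.

Group and attachment point change together from compound 3 to compound 4, so their separate contributions stay unknown. Also open, as far as these compounds go, is how an amine or a carboxylic acid on the benzyl group would behave.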